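Acetyl to methyl on the aryl oxygen: outlook for compound 4

The source may hold more compounds than are shown below. What is called first, only, known or untested is meant among the compounds shown, and "the series" means these compounds.

Values so far in a functional assay on KB cells (Homo sapiens) for cytotoxicity, read by MTT assay, with a stated time of 72 h; on this read-out higher numbers stand for an effect only at larger amounts of compound and lower numbers for an effect already at smaller amounts:

Compound 1 `CCOc1c(-c2occ(C)c2C(=O)O)ccc2c(CC)cccc12`: > 10 ug/mL, a limit of the assay.
Compound 2 `CCOc1c(-c2occ(C)c2CO)ccc2c(CC)cccc12`: > 10 ug/mL, a limit of the assay.
Compound 3 `CCc1cccc2c(OC(C)=O)c(-c3occ(C)c3COC(C)=O)ccc12`: > 10 ug/mL, a limit of the assay.

Compound 3 therefore stands at the same place as everything else measured here, namely (the limit of > 10 ug/mL in this assay, at which 3 of the 3 values shown sit); no number has yet been read for any member of the series. Among the measured compounds shown here, the one step between measured compounds, a step that the two limits leave unreadable from compound 1 to compound 2, cannot be sized, as both ends are limits.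

Compound 4 `CCc1cccc2c(OC)c(-c3occ(C)c3COC(C)=O)ccc12` differs from compound 3 by methyl in place of acetyl on an oxygen on an aromatic ring. For the measured compounds named here, no measured step touches this oxygen, and the single step available is unreadable, so there is nothing to suggest the change should bring the value into the readable range. The expectation is that compound 4 again returns a limit in this assay, with the step that the limit leaves unreadable from compound 3 to compound 4 estimated as none beyond the scatter. Compound 4 is thus estimated at 20 ug/mL, in the range 8 ug/mL to 60 ug/mL.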

Compound 4, concentration for half-maximal effect: > 10 ug/mL
Compound 4 gave a limit, no number (the forecaster's own chance of this, stated with the estimate: 85%); the middle value does not contradict the limit.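

In this assay compound 4 gives > 10 ug/mL, a limit and not a number. Compound 3 also gives a limit there, so the step between compound 3 and compound 4 cannot be read. The compounds shown leave open whether any change on the shared core gives a readable number, as all sit at one place: the limit of > 10 ug/mL in this assay, at which 4 of the 4 values shown sit.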